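Isobutyl for Isopropyl: Expected Exposure of Compound 4

A few compounds are considered here, and "the series" means these few. Any claim that something is new, unique, unknown or untested is made for them only; others in the source may bear on it.

Measured in an ADME assay on the whole organism (plasma) for pharmacokinetics, with Rattus norvegicus as the target, at a dose of 10 mg/kg by the oral route; a higher number here means more compound in the circulation at the dose given, a lower number less compound in the circulation:
Compound 1 `CC(C)(CO)Cn1ncn(-c2ccc(N3CCN(c4ccc(OC[C@H]5CO[C@](Cn6cncn6)(c6ccc(F)cc6F)O5)cc4)CC3)cn2)c1=O` gives 1900 ng.h/mL.
Compound 2 `CC(C)n1ncn(-c2ccc(N3CCN(c4ccc(OC[C@H]5CO[C@](Cn6cncn6)(c6ccc(F)cc6F)O5)cc4)CC3)nc2)c1=O` gives 2710 ng.h/mL.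
Compound 3 `CC(C)n1ncn(-c2ccc(N3CCN(c4ccc(OC[C@H]5CO[C@](Cn6cncn6)(c6ccc(F)cc6F)O5)cc4)CC3)cn2)c1=O` gives 1220 ng.h/mL.

Compound 2 has the highest number of the three. Its nearest neighbour is compound 1, and that gap is within the scatter; the gap from compound 2 to compound 3 is beyond it. Among the compounds with values here, the only step between two measured compounds that differ in one place, a 1.6-fold lower number from compound 1 to compound 3 (0.19 log units; within the scatter), swaps the group on the aromatic nitrogen and stays within the scatter.

Compound 4 `CC(C)Cn1ncn(-c2ccc(N3CCN(c4ccc(OC[C@H]5CO[C@](Cn6cncn6)(c6ccc(F)cc6F)O5)cc4)CC3)nc2)c1=O` differs from compound 2 by isobutyl in place of isopropyl on an aromatic nitrogen. Within the data shown here, no measured pair shows exactly this swap, so the expectation rests on the single neighbouring step, which suggests that changing the group on this aromatic nitrogen moves the number little. Compound 4 is therefore expected to land close to compound 2, with an estimated step of a 1.2-fold lower number from compound 2 to compound 4 (0.07 log units; within the scatter), not beyond the scatter in either direction. In this assay compound 4 is estimated at 2300 ng.h/mL, with a range from 900 ng.h/mL to 5500 ng.h/mL.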

Compound 4, area under the concentration-time curve: 1610 ng.h/mL
Compound 4: the middle estimate sits 1.4-fold (0.15 log units) above what was measured; the range from low to high includes it.
By their numbers in this assay, from the lowest: compounds 3, 4, 1 and 2 (each within the scatter of the next, the first and the last beyond it).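

In this assay the change from isopropyl to isobutyl on the aromatic nitrogen gives a 1.7-fold lower number from compound 2 to compound 4 (0.23 log units; within the scatter), so one extra carbon in this branched group leaves the number within the usual scatter. Within the data shown here, this is the first direct reading of this swap, and it agrees with the earlier step at the same nitrogen, a 1.6-fold lower number from compound 1 to compound 3 (0.19 log units; within the scatter), so both changes read so far at this position stay within the scatter and neither goes against the other. Nothing available explains why the exposure holds across these groups.

On these data alone, these groups are all carbon chains, apart from the hydroxymethyl-bearing chain of compound 1, so a basic amine or a carboxylic acid on this nitrogen remains untested here. As far as these compounds go, whether a cyclopropyl ring or a much longer chain would also stay within the scatter remains open as well.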